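The source may report more compounds than this note shows. Statements on the series, on what has been measured and on what is new or still open speak of the compounds shown alone.

Readings in a functional assay on SiHa cells (Homo sapiens) for antiproliferative activity, read by CCK-8 assay, with a stated time of 72 h (on this read-out higher numbers stand for weaker inhibition and lower numbers for stronger inhibition), for the three measured members of the series:

compound 1, `COc1ccc(-c2cncnc2-c2cc(OC)c(OC)c(OC)c2)cc1F`: 3340 nM
compound 2, `COc1ccc(-c2cncnc2-c2cc(OC)c(OC)c(OC)c2)cc1Cl`: 1330 nM
compound 3, `CCOc1ccc(-c2cncnc2-c2cc(OC)c(OC)c(OC)c2)cc1F`: 800 nM

All three share one core and differ only on the ring that carries the alkoxy group. Compound 1 and compound 2 differ by chloro in place of fluoro on an aromatic carbon, and that change brought a 2.5-fold lower number from compound 1 to compound 2 (0.40 log units; beyond the scatter). Compound 1 and compound 3 differ by methyl in place of hydrogen on a saturated chain carbon bound to an oxygen on an aromatic ring, which brought a 4.2-fold lower number from compound 1 to compound 3 (0.62 log units; beyond the scatter). Compound 3 holds the lowest number of the three, but compound 2 lies within the scatter of it, so no order between compound 2 and compound 3 is claimed.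

Compound 4, `CCOc1ccc(-c2cncnc2-c2cc(OC)c(OC)c(OC)c2)cc1Cl`, is not yet measured in this assay. It differs from compound 3 by chloro in place of fluoro on an aromatic carbon. Among the compounds with values here, this is the same kind of change as the one from compound 1 to compound 2, though not the same: in the earlier pair the changed carbon is ortho to a methoxy group (2 heavy atoms), whereas in compound 3 and compound 4 it is ortho to an ethoxy group (3 heavy atoms). Within the data shown here, only one measured instance of this change exists, so the expectation rests on a single step. Among the measured compounds shown here, compound 4 is expected to show a 2.0-fold lower number from compound 3 to compound 4 (0.30 log units; within the scatter), kept slightly more cautious than the earlier step because a 2.5-fold lower number from compound 1 to compound 2 (0.40 log units; beyond the scatter) is the only measured instance and sits beside a shorter alkoxy group. Compound 4 is therefore estimated at 400 nM, with a plausible range from 200 nM to 900 nM.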

Compound 4, half-maximal inhibitory concentration: 150 nM
Compound 4: middle estimate off by 2.7-fold (0.43 log units), on the high side; the measured number lies below the stated range.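

In this assay, chloro in place of fluoro gave a 5.3-fold lower number from compound 3 to compound 4 (0.73 log units; beyond the scatter), and the earlier step with the same change points the same way, with no difference between the two that stands clear of the scatter: the same change on two cores in this assay, a 2.5-fold lower number (0.40 log units; beyond the scatter) from compound 1 to compound 2 and a 5.3-fold lower number (0.73 log units; beyond the scatter) from compound 3 to compound 4, 2.1-fold (0.33 log units) apart, within the scatter of two such steps

Adding the methyl to the saturated chain carbon bound to the oxygen, which turns methoxy into ethoxy, also carried over in direction, with an 8.9-fold lower number from compound 2 to compound 4 (0.95 log units; beyond the scatter) and again no clear difference in size: the same change on two cores in this assay, a 4.2-fold lower number (0.62 log units; beyond the scatter) from compound 1 to compound 3 and an 8.9-fold lower number (0.95 log units; beyond the scatter) from compound 2 to compound 4, 2.1-fold (0.33 log units) apart, within the scatter of two such steps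

This shows that both changes kept their direction across the two cores in these four compounds, but it does not show that the larger steps into compound 4 are a real enhancement, and with one square of four compounds and two instances of each change, it gives no general rule for carrying either change to other cores.

The compounds shown leave open whether the trend from fluoro to chloro continues to bromo or a larger group such as trifluoromethyl on the same aromatic carbon. They also leave open whether a longer chain such as propoxy, or an alkoxy chain ending in an amine, would extend the trend from methoxy to ethoxy.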